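The source may report more compounds than this note shows. Statements on the series, on what has been measured and on what is new or still open speak of the compounds shown alone.

In an in vitro ADME assay on microsomes from liver (Homo sapiens) for metabolic stability (a higher number here means faster removal of the compound, a lower number slower removal), three compounds have been measured so far.

- Compound 1 `Cc1ccc(-n2c(C)nnc2C2CCN(c3ccccn3)CC2)cc1` gives 40 mL.min-1.g-1 as its reading
- Compound 2 `Cc1nnc(C2CCN(c3ccccn3)CC2)n1-c1ccc(C#N)cc1` gives < 8 mL.min-1.g-1 as a limit of the assay and not a number
- Compound 3 `CCCCc1nnc(C2CCN(c3ccccn3)CC2)n1Cc1ccccc1` gives 154 mL.min-1.g-1 as its reading

Compound 3 at 154 mL.min-1.g-1 stands highest, ahead of compound 1 at 40 mL.min-1.g-1 by more than the scatter. Compound 4 `c1ccc(Cn2c(Cn3nccn3)nnc2C2CCN(c3ccccn3)CC2)cc1` differs from compound 3 by the change 2H-1,2,3-triazol-2-yl in place of propyl on a saturated chain carbon bound to an aromatic carbon in which 2H-1,2,3-triazol-2-yl takes the place of propyl on a saturated chain carbon bound to an aromatic carbon.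

For the measured compounds named here, only one measured step offers any guide, namely an at least 5.0-fold lower number from compound 1 to compound 2 (0.69 log units; beyond the scatter) for cyano in place of methyl on an aromatic carbon. It is a different change at a different kind of carbon, so it bears on this one only loosely. Resting on an at least 5.0-fold lower number from compound 1 to compound 2 (0.69 log units; beyond the scatter) alone, a lower number of moderate size is expected for compound 4 in this assay as well. The expected step is a 2.6-fold lower number from compound 3 to compound 4 (0.41 log units; beyond the scatter) and it is only loosely estimated. For compound 4 the estimate is 60 mL.min-1.g-1 with an expected range from 20 mL.min-1.g-1 to 160 mL.min-1.g-1 in this reading.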

Compound 4, intrinsic clearance in microsomes: 19 mL.min-1.g-1
For compound 4 the middle estimate is 3.2-fold (0.50 log units) above the measured one, outside the stated range (below it).
By their numbers in this assay, from the lowest: compound 4; then compound 1; then compound 3. At a limit, below all of these: compound 2.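

In this assay, the exchange of propyl for 2H-1,2,3-triazol-2-yl on a saturated chain carbon bound to an aromatic carbon gives an 8.1-fold lower number from compound 3 to compound 4 (0.91 log units; beyond the scatter), so a change at this place can shift the number by more than the scatter. For the compounds shown here, the only earlier step, an at least 5.0-fold lower number from compound 1 to compound 2 (0.69 log units; beyond the scatter), rests on a limit of the assay and concerns a different change at an aromatic carbon; the two steps run in the same direction, but they are too few and too unlike to make a pattern. Nothing shown here gives a cause for the lower number at this place.

The compounds shown leave open whether the step follows from the loss of propyl or from the entry of 2H-1,2,3-triazol-2-yl. On these data alone, how an ethyl chain, an amine or a carboxylic acid would read at this place also remains open.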